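The source may report more compounds than this note shows. Statements on the series, on what has been measured and on what is new or still open speak of the compounds shown alone.

Compound 3 `CCC(=O)Nc1cccc(S(=O)(=O)N2CCC(NC(=O)c3n[nH]cc3NC(=O)c3c(Cl)cccc3Cl)CC2)c1` carries a propanoylamino group on the phenyl ring attached to the sulfonyl. In an assay on HEK293 cells for inhibition of cyclin-dependent kinase 14 (Homo sapiens), with a stated time of 4 h (on this read-out lower numbers stand for stronger inhibition and higher numbers for weaker inhibition), compound 3 gives > 1000 nM, which is a limit of the assay and not a number. Compound 3 therefore stands at the limit of > 1000 nM in this assay, at which 1 of the 3 values shown sits. Compound 4 `C=CC(=O)Nc1cccc(S(=O)(=O)N2CCC(NC(=O)c3n[nH]cc3NC(=O)c3c(Cl)cccc3Cl)CC2)c1` differs from compound 3 by vinyl in place of ethyl on a carbonyl carbon. Two other compounds frame this series: compound 1 `CN(C)C/C=C/C(=O)Nc1cccc(S(=O)(=O)N2CCC(NC(=O)c3n[nH]cc3NC(=O)c3ccccc3)CC2)c1`, which gives 1000 nM in this assay, and compound 2 `COc1cccc(Cl)c1C(=O)Nc1c[nH]nc1C(=O)NC1CCN(S(=O)(=O)c2cccc(NC(=O)/C=C/CN(C)C)c2)CC1`, which gives 50 nM. For the measured compounds named here, the only measured step, a 20-fold lower number from compound 1 to compound 2 (1.30 log units; beyond the scatter), concerns the aryl group on the other carbonyl and not the acylamino group changed here, so no measured step bears directly on the move from compound 3 to compound 4. What can be said is that both compound 1 and compound 2 carry an unsaturated acylamino group and both give a number rather than a limit. On that basis compound 4 is expected to give a number, estimated at 100 nM with a range from 20 nM to 1000 nM. This estimate means a step of an at least 10-fold lower number from compound 3 to compound 4 (1.00 log units; beyond the scatter), a lower number expected for compound 4.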

Compound 4, half-maximal inhibitory concentration: 1000 nM
Compound 4: the middle estimate sits 10-fold (1.00 log units) below what was measured; measured number inside the range.
By their numbers in this assay, from the lowest: compound 2; then compounds 1 and 4 (each within the scatter of the next).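

For the compounds shown here, this pair is the first look at the acylamino group itself: the earlier step changed only the aryl group on the other carbonyl. With vinyl in place of ethyl on a carbonyl carbon, compound 4 gives a number in this assay, 1000 nM, at this position. This is a number no higher from compound 3 to compound 4 (the limit leaves the size open) with ethyl changed to vinyl. Compound 3 stands at a limit of the assay and not at a number, so the size of this step cannot be read: the limit of > 1000 nM in this assay, at which 1 of the 4 values shown sits.

Going by these compounds, whether vinyl gives any real gain over ethyl therefore remains open, as the step could be very small or much larger. Also open, on these data alone, is how other groups on this carbonyl, such as a chloromethyl or an ethynyl group, would compare on the same core.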